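Swapping Chloro for Trifluoromethyl on the Aryl Urea

The compounds below may be only part of what the source reports. "The series", "measured", "known", "first", "only" and "open" are said of these compounds alone.

Measured compounds:
compound 1, `COc1cc(NC(C)CCCNC(=O)Nc2cccc(Cl)c2)c2ncccc2c1`: 21000 nM
compound 2, `COc1cc(NC(C)CCCNC(=O)Nc2ccc(Br)cc2)c2ncccc2c1`: 25000 nM
compound 3, `COc1cc(NC(C)CCCNC(=O)Nc2cc(C(F)(F)F)cc(C(F)(F)F)c2)c2ncccc2c1`: 12000 nM

All three share one core and differ only in the substituted phenyl ring attached through the urea. In a functional assay on MOLT-4 cells (Homo sapiens) for inhibition, read by MTT assay, with a stated time of 72 h (on this read-out higher numbers stand for weaker inhibition and lower numbers for stronger inhibition), compound 1 gives 21000 nM, which sits second highest of the three numbers; compound 2 lies nearest with a number that is within the scatter of compound 1, and compound 3 lies furthest, also within the scatter, so none of the three can be called stronger or weaker than the others on this read-out.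

The new compound is compound 4, `COc1cc(NC(C)CCCNC(=O)Nc2cccc(C(F)(F)F)c2)c2ncccc2c1`. Compared with compound 1 the change is trifluoromethyl in place of chloro on an aromatic carbon.

Within the data shown here, only one measured step is available for guidance: a 1.2-fold higher number from compound 1 to compound 2 (0.08 log units; within the scatter). That step changed the halogen and its position on the ring and produced no movement beyond the scatter. Compound 3, which carries two trifluoromethyl groups, gives a number within the scatter of compound 1 as well. Taken together, the numbers give no sign that changing the substituent on this ring moves the read-out appreciably. The step of a 1.2-fold lower number from compound 1 to compound 4 (0.09 log units; within the scatter) is therefore expected to stay within the scatter. Compound 4 is estimated at 17000 nM, with a range from 8000 nM to 36000 nM.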

Compound 4, half-maximal inhibitory concentration: 20000 nM
Compound 4: middle estimate off by 1.2-fold (0.07 log units), on the low side, and the stated range covers the measured number.
By their numbers in this assay, from the lowest: compounds 3, 4, 1 and 2 (each within the scatter of the next, the first and the last beyond it).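

In this assay, replacing chloro with trifluoromethyl on this ring puts 4 heavy atoms where 1 stood, and the result is a 1.1-fold lower number from compound 1 to compound 4 (0.02 log units; within the scatter). Among these compounds, this is the first direct reading of a single trifluoromethyl on this ring: against the compound with two such groups, the comparison gives a 1.7-fold higher number from compound 3 to compound 4 (0.22 log units; within the scatter), and against the 4-bromophenyl urea it gives a 1.3-fold lower number from compound 2 to compound 4 (0.10 log units; within the scatter), so none of these three steps separates the compounds. Nothing available explains why these changes to the ring leave the number within the scatter.

Every aryl group shown carries only halogen or trifluoromethyl substituents, so it remains open whether an amine, a carboxylic acid or a hydroxyl group on this ring would move the number beyond the scatter. The chain joining the urea to the shared core is also the same in all four compounds, which leaves open what a shorter or longer chain would do, or an amide in place of the urea.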